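The compounds below may be only part of what the source reports. "The series", "measured", "known", "first", "only" and "open" are said of these compounds alone.

Compound 3 `CCn1c(-c2ccc(C(F)(F)F)nc2)nc2c(O[C@H]3CCN(C(=O)N4CC(OC)C4)C3)ncnc21` gives 2.1 in a physicochemical assay for lipophilicity, read by HPLC; on this read-out lower numbers stand for lower lipophilicity and higher numbers for higher lipophilicity. Compound 1 `CCn1c(-c2cnc(C)nc2)nc2c(N[C@H]3CCN(C(=O)C4CC(F)(F)C4)C3)ncnc21` gives 1.5 in this assay, and compound 2 `CCn1c(-c2cnc(C)nc2)nc2c(N[C@H]3CCN(C(=O)C4CCC4)C3)ncnc21` gives 1.2. Among the measured compounds shown here, of the three numbers known, that of compound 3 is the highest, and its gaps to compound 1 and to compound 2 both lie outside the usual scatter. Compound 4 `CCn1c(-c2ccc(C(F)(F)F)nc2)nc2c(O[C@H]3CCN(C(=O)C4CC4)C3)ncnc21` differs from compound 3 in one place: cyclopropyl in place of 3-methoxyazetidin-1-yl on a carbonyl carbon. For the measured compounds named here, the only measured step at the same kind of position is the one in which the number moved a number 0.30 log units lower from compound 1 to compound 2 (within the scatter); that change is of a different kind, and the data hold no closer comparison. Since the group that leaves carries a hydrogen-bond acceptor and the group that enters carries none, a modest rise is expected, and for compound 4 the expected step is a number 0.40 log units higher from compound 3 to compound 4 (beyond the scatter). The estimate for compound 4 is 2.5, with a range from 2 to 3.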

Compound 4, distribution coefficient: 2.3
Estimate against measurement, compound 4: 0.20 log units above; measured number inside the range.
By their numbers in this assay, from the lowest: compounds 2 and 1 (each within the scatter of the next); then compounds 3 and 4 (each within the scatter of the next).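

Exchanging 3-methoxyazetidin-1-yl, with 6 heavy atoms and 1 hydrogen-bond acceptor, for cyclopropyl, with 3 heavy atoms and 0 hydrogen-bond acceptors, on a carbonyl carbon gives a number 0.20 log units higher from compound 3 to compound 4 (within the scatter) in this assay. Thus a replacement of the whole group at this place, and not only the cyclobutyl for 3,3-difluorocyclobutyl exchange seen earlier, stays within the scatter. Nothing available explains this result. Still open, as far as these compounds go, is how a dimethylamino group, a longer alkyl chain or a carboxylic acid would read on this carbonyl carbon, and whether the same exchange gives a similar step on the rest of compound 1.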